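Sulfamoyl for Amino on a Shared Kinase-Binding Core

The source may hold more compounds than are shown below. What is called first, only, known or untested is meant among the compounds shown, and "the series" means these compounds.

Measured compounds:
Compound 1, `CCCS(=O)(=O)Nc1ccc(F)c(C(=O)c2n[nH]c3ncc(-c4ccccc4O)cc23)c1F`, 9%
Compound 2, `CCCS(=O)(=O)Nc1ccc(F)c(C(=O)c2n[nH]c3ncc(-c4ccc(N)cc4)cc23)c1F`, 0.1%

In an assay for binding affinity to dual specificity mitogen-activated protein kinase kinase 4 (Homo sapiens), read by KINOMEscan, tested at 100 nM (on this read-out lower numbers stand for a stronger effect and higher numbers for a weaker effect at the one concentration tested), compound 2 gives 0.1%, the lowest of the two numbers, while compound 1 gives 9%. Within the data shown here, the one measured step, a number 8.9 percentage points lower from compound 1 to compound 2 (within the scatter), swaps one group on the same aromatic carbon and stays within the scatter, so the two compounds cannot be ordered.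

Compound 3, `CCCS(=O)(=O)Nc1ccc(F)c(C(=O)c2n[nH]c3ncc(-c4ccc(S(N)(=O)=O)cc4)cc23)c1F`, differs from compound 2 by sulfamoyl in place of amino on an aromatic carbon. Among the measured compounds shown here, the swap sits at the same aromatic carbon as the step from compound 1 to compound 2, which is the only measured step that bears on it, and that step was small. Compound 3 is therefore expected to show a step of a number 2.9 percentage points higher from compound 2 to compound 3 (within the scatter), none beyond the scatter, with the number unable to fall much further because compound 2 already gives 0.1%. For compound 3 the expected value is 3%, estimated in the range 0.1% to 15%.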

Compound 3, a percentage reported as activity, at one concentration (the size of the read-out at that concentration, not a potency): 0.25%
For compound 3 the middle estimate is 2.8 percentage points above the measured one; the range from low to high includes it.
By their numbers in this assay, from the lowest: compounds 2, 3 and 1 (each within the scatter of the next).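

Sulfamoyl is the larger of the two groups by heavy-atom count, yet in this assay replacing amino at this aromatic carbon, para to a large group, gives a step of a number 0.2 percentage points higher from compound 2 to compound 3 (within the scatter), so this change separates compound 2 and compound 3 no more than the earlier swap separated compound 1 and compound 2. The second new step, a number 8.8 percentage points lower from compound 1 to compound 3 (within the scatter), likewise leaves 4-sulfamoylphenyl and 2-hydroxyphenyl unordered, and all three aryl groups shown now read as one group within the scatter. No outside evidence bears on this result.

Going by these compounds, whether a carboxylic acid or a dimethylamino group on the same aromatic carbon would give a step beyond the scatter remains open. So does whether a lower tested concentration would separate compound 1, compound 2 and compound 3.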